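The source may hold more compounds than are shown below. What is called first, only, known or untested is meant among the compounds shown, and "the series" means these compounds.

Measured so far in a functional assay on HEK293 cells for antagonist activity at transient receptor potential cation channel subfamily V member 1 (Homo sapiens), read by calcium flux; on this read-out higher numbers stand for weaker inhibition and lower numbers for stronger inhibition:
compound 1, `CC(C)(C)c1ccc(NC(=O)c2ccc(SC(F)(F)F)cc2)cc1`, gives 253 nM.
compound 2, `O=C(NCCN1CCCc2ccccc21)c1ccc(OC(F)(F)F)cc1`, gives 4600 nM.
compound 3, `COc1ccc2c(c1)N(CCNC(=O)c1ccc(OC(F)(F)F)cc1)CCC2`, gives > 10000 nM, which is a limit of the assay and not a number.

Compound 3 therefore stands at the edge of what the assay reports, at the limit of > 10000 nM in this assay, at which 1 of the 3 values shown sits, and its true value is known only to lie beyond that point. Within the data shown here, the one measured step that leads to it is an at least 2.1-fold higher number from compound 2 to compound 3 (0.33 log units; beyond the scatter), so the methoxy group on the aromatic carbon of compound 3 is tied to a weakening that is at least modest.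

Compound 4, `O=C(NCCN1CCCc2ccc(O)cc21)c1ccc(OC(F)(F)F)cc1`, differs from compound 3 by hydrogen in place of methyl on an oxygen on an aromatic ring. Among the measured compounds shown here, no measured pair shows this methoxy-to-hydroxy change directly; the step from compound 2 to compound 3 bears on it only in that the oxygen on the aromatic ring is kept while the methyl is removed, so compound 4 lies between the two measured structures rather than on a measured line. Since compound 3 is known only as a limit, the expectation for compound 4 is a value near that limit, with a fair chance that this assay again reports only a limit. Compound 4 is estimated at 9000 nM, in the range 3000 nM to 30000 nM, which as a step means an expected at least 1.1-fold lower number from compound 3 to compound 4 (0.04 log units; that floor lies within the scatter).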

Compound 4, half-maximal inhibitory concentration: 960 nM
For compound 4 the middle estimate is 9.4-fold (0.97 log units) above the measured one; the whole stated range lies above it.
By their numbers in this assay, from the lowest: compound 1; then compound 4; then compound 2. At a limit, above all of these: compound 3.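

Until this result, the only change shown on this aromatic carbon in this assay went towards weaker inhibition; hydroxy in place of hydrogen goes the other way, with a 4.8-fold lower number from compound 2 to compound 4 (0.68 log units; beyond the scatter), so a group at this place need not weaken inhibition. The change at the oxygen itself is large, with an at least 10-fold lower number from compound 3 to compound 4 (1.01 log units; beyond the scatter), and among these compounds it is the methyl on that oxygen that separates the weakening seen with methoxy from the strengthening seen with hydroxy. That step can be read only as a floor, because compound 3 is held at a limit and not a number: the limit of > 10000 nM in this assay, at which 1 of the 4 values shown sits.

The compounds shown leave open how far the step from methoxy to hydroxy really reaches and whether the gain is special to hydroxy or would also appear with an amine, a carboxylic acid or a fluorine atom on the same aromatic carbon. They also leave open whether hydroxy would go with stronger inhibition on other carbons of that aromatic ring, or on a core with a different chain to the amide.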